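This account rests on a few compounds, and the source may have more. Where it says the series, first, only, none or still open, it means among the compounds named here.

In an assay on isolated protein for inhibition of Nicotinamide phosphoribosyltransferase (Homo sapiens), read by TR-FRET, with a stated time of 3 h (on this read-out lower numbers stand for stronger inhibition and higher numbers for weaker inhibition), compound 2 `O=C(Nc1ccc(-c2n[nH]c(=O)c3c2CCCC3)cc1)N1Cc2ccc(F)cc2C1` gives 45 nM, the lowest of the two numbers in hand. Compound 1 `O=C(Nc1ccc(-c2n[nH]c(=O)c3c2CCCC3)cc1)N1Cc2ccccc2C1` gives 105 nM in this assay. Among the compounds with values here, the one measured step, a 2.3-fold lower number from compound 1 to compound 2 (0.37 log units; beyond the scatter), is the only guide available. Compound 3 `O=C(Nc1ccc(-c2n[nH]c(=O)c3c2CCCC3)cc1)N1Cc2ccc(Cl)cc2C1` carries the change (chloro in place of fluoro on an aromatic carbon). Within the data shown here, no measured step covers chloro against fluoro, so the single halogen step is the only bearing, and it was modest; a step of similar or smaller size is expected here, with no firm direction. For compound 3 the expected step is a 1.3-fold lower number from compound 2 to compound 3 (0.11 log units; within the scatter). Compound 3 is estimated at 35 nM, within 15 nM to 90 nM.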

Compound 3, half-maximal inhibitory concentration: 44 nM
Compound 3: the middle estimate sits 1.3-fold (0.10 log units) below what was measured; the measured number falls inside the stated range.
By their numbers in this assay, from the lowest: compounds 3 and 2 (each within the scatter of the next); then compound 1.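

Chloro and fluoro cannot be told apart at this aromatic carbon, with a 1.0-fold lower number from compound 2 to compound 3 (0.01 log units; within the scatter) and so no order between the two halogens. Chloro in place of hydrogen gives a 2.4-fold lower number from compound 1 to compound 3 (0.38 log units; beyond the scatter), so the earlier gain over hydrogen is not confined to fluoro but holds for both halogens shown. Nothing at hand explains why the two halogens match.

As far as these compounds go, whether bromo, methoxy, an amine or a nitrile would hold the same level at this carbon stays open. So does whether chloro at another carbon of this ring would do the same.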